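A few compounds are considered here, and "the series" means these few. Any claim that something is new, unique, unknown or untested is made for them only; others in the source may bear on it.

Of the compounds shown here, three sharing one core have been measured in a functional assay on A549 cells (Homo sapiens) for antiproliferative activity, read by sulforhodamine B assay, with a stated time of 48 h; a higher number here means a weaker inhibitor of growth, a lower number a stronger inhibitor of growth. Compound 1 `COc1ccc(Nc2nc(NC3CCCC3)c3ccccc3n2)cc1` gives 10100 nM, compound 2 `COc1ccc(Nc2nc(NC3CC3)c3ccccc3n2)cc1` gives 13000 nM, and compound 3 `COc1ccc(N(C)c2nc(NC3CCCC3)c3ccccc3n2)cc1` gives 9400 nM. Compound 3 therefore stands level with the other two, since its number lies within the ordinary scatter of both.

The unmeasured compound 4 `CNc1nc(N(C)c2ccc(OC)cc2)nc2ccccc12` differs from compound 3 by a single change: methyl in place of cyclopentyl on a nitrogen on an aromatic ring. In words, this is methyl in place of cyclopentyl on a nitrogen on an aromatic ring.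

The closest evidence is a change at the same place, where cyclopropyl in place of cyclopentyl gave a 1.3-fold higher number from compound 1 to compound 2 (0.11 log units; within the scatter). The other measured step, methyl in place of hydrogen on a nitrogen on an aromatic ring, gave a 1.1-fold lower number from compound 1 to compound 3 (0.03 log units; within the scatter). Neither step goes beyond the scatter, so varying these groups has so far moved this assay very little. Methyl is a larger departure from cyclopentyl than cyclopropyl is, however, and no measured compound carries so small a group there. A slightly higher number, or no change beyond the scatter, is the reasonable expectation.

The expected step is a 1.4-fold higher number from compound 3 to compound 4 (0.14 log units; within the scatter). For compound 4 the estimated value is 13000 nM, with an expected range of 6500 nM to 27000 nM.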

Compound 4, concentration for 50% growth inhibition: 19900 nM
Compound 4: the middle estimate sits 1.5-fold (0.18 log units) below what was measured, and the stated range covers the measured number.
By their numbers in this assay, from the lowest: compounds 3, 1, 2 and 4 (each within the scatter of the next, the first and the last beyond it).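

In this assay, replacing cyclopentyl with methyl on this nitrogen gives a 2.1-fold higher number from compound 3 to compound 4 (0.33 log units; beyond the scatter), a modest change, but the first one among these compounds to go beyond the scatter. This shows that the group on this nitrogen can affect the number after all: the earlier replacement of cyclopentyl by cyclopropyl, a 1.3-fold higher number from compound 1 to compound 2 (0.11 log units; within the scatter), had suggested little sensitivity, whereas methyl, which has a single carbon and no ring, weakens growth inhibition measurably, though that earlier step was taken with a hydrogen rather than a methyl on the other nitrogen. Nothing measured here explains why the number rises with this change.

From the compounds shown here alone, it remains open whether the same replacement would have a similar effect with a hydrogen on the other nitrogen, as in the core of compound 1, so the result cannot yet be generalised beyond the pair it comes from. It is also unknown how this nitrogen would respond to a group of a different kind or size, such as a cyclohexyl ring, a longer carbon chain, or a chain ending in an amine or a carboxylic acid.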